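Oxygen for Sulfur in the Linker of Compound 1

The source may hold more compounds than are shown below. What is called first, only, known or untested is meant among the compounds shown, and "the series" means these compounds.

The account concerns two measured compounds and one that awaits measurement. Compound 1, `NS(=O)(=O)NCCSc1nonc1/C(=N/O)Nc1ccc(F)c(Br)c1`, was tested in an assay for inhibition of Indoleamine 2,3-dioxygenase 1 (Homo sapiens), read by fluorescence, with a stated time of 24 h (a higher number here means a weaker inhibitor, a lower number a stronger inhibitor), where compound 1 gives 2.8 nM. Compound 2, `N#Cc1cccc(N/C(=N\O)c2nonc2SCCNC(=O)CS(N)(=O)=O)c1`, carries a different aryl group and a longer linker; in this assay compound 2 gives 44 nM. Of the two numbers, that of compound 1 is the lower, and the gap to compound 2 lies beyond the scatter of repeated measurements, so compound 1 is the stronger inhibitor of the pair.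

The next compound, compound 3, `NS(=O)(=O)NCCOc1nonc1/C(=N/O)Nc1ccc(F)c(Br)c1`, keeps the aryl group and core of compound 1 and alters only the linker: 2-(sulfamoylamino)ethoxy in place of (2-(sulfamoylamino)ethyl)sulfanyl on an aromatic carbon. Within the data shown here, no measured pair shows this particular change, so there is no step to lean on. The expectation is that compound 3 loses a little against compound 1, a step of a 2.5-fold higher number from compound 1 to compound 3 (0.40 log units; beyond the scatter) in this assay, with a direction toward weaker inhibition but not far beyond the scatter. Compound 3 is therefore estimated at 7 nM, with a range from 2 nM to 25 nM.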

Compound 3, half-maximal inhibitory concentration: 12 nM
The estimate for compound 3 lay 1.7-fold (0.23 log units) below the measured number; the range from low to high includes it.
By their numbers in this assay, from the lowest: compound 1; then compound 3; then compound 2.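

In this assay, putting 2-(sulfamoylamino)ethoxy in place of (2-(sulfamoylamino)ethyl)sulfanyl on an aromatic carbon of the shared core gives a 4.3-fold higher number from compound 1 to compound 3 (0.63 log units; beyond the scatter), a modest loss that lies beyond the scatter, and compound 3 remains a nanomolar inhibitor at 12 nM. Among these compounds, this is the first comparison here in which only one place changes, since compound 2 differs from compound 1 in both the aryl group and the linker, and the step therefore shows that the atom joining this chain to the core affects the reading even though the two groups have the same counts of hydrogen-bond donors and acceptors. Nothing available accounts for the size or direction of this step.

The compounds shown leave open how an amine nitrogen or a methylene carbon would compare with sulfur and oxygen as the joining atom, and how a longer chain leading to the sulfamoylamino group would read at this position. They also leave open whether the exchange of oxygen for sulfur carries the same step when the aryl group of compound 1 is replaced by that of compound 2.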